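The source may hold more compounds than are shown below. What is called first, only, known or untested is meant among the compounds shown, and "the series" means these compounds.

Of the compounds shown here, two from this series have so far been measured in a physicochemical assay for lipophilicity, read by HPLC, in phosphate buffer, measured as chromatographic lipophilicity, at pH 7.4; on this read-out lower numbers stand for lower lipophilicity and higher numbers for higher lipophilicity. Compound 1 `COc1ccc2nc(C)cc(OC(C)(C)C(=O)Nc3cc(C)cc(C)c3)c2c1` gives 6.37 in this assay. Compound 2 `COc1ccc(NC(=O)COc2cc(C)nc3ccc(OC)cc23)cc1` gives 4.22 in this assay, the lower of the two numbers, and the gap to compound 1 is beyond the usual scatter of such measurements. Compound 3 `COc1ccc2nc(C)cc(OCC(=O)Nc3ccccn3)c2c1` has not yet been measured. Compared with compound 2 it carries a different group on the amide-type nitrogen: pyridin-2-yl in place of 4-methoxyphenyl on an amide-type nitrogen. Going by the values given here, no pair of measured compounds differs in one place only, so no measured step shows how a change of this kind moves this assay. On the structures alone, a downward step that goes beyond the scatter is expected, since a ring with one nitrogen enters where a ring of carbon only, with a methoxy group on it, leaves. The estimate corresponds to an expected step of a number 1.02 log units lower from compound 2 to compound 3 (beyond the scatter). In this assay compound 3 is therefore expected to give about 3.2, with a range from 2.5 to 3.9.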

Compound 3, distribution coefficient: 3.49
Compound 3: the middle estimate sits 0.29 log units below what was measured, and the stated range covers the measured number.
By their numbers in this assay, from the lowest: compound 3; then compound 2; then compound 1.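

In this assay, going by these compounds alone, the change from 4-methoxyphenyl to pyridin-2-yl on the amide-type nitrogen gives the first step that can be read at a single place: a number 0.73 log units lower from compound 2 to compound 3 (beyond the scatter). This shows that the read-out responds to the choice of ring at this position, even though the two groups have the same counts of hydrogen-bond donors and acceptors and neither carries a net charge. The swap changes two things at once, removing the methoxy group and placing a nitrogen in the ring, and nothing available assigns the step to either one or explains it.

A plain phenyl group on the same nitrogen would help separate those two parts of the change, while pyridin-3-yl or pyridin-4-yl would test whether the place of the ring nitrogen matters. From the compounds shown here alone, compound 1 differs from compound 2 and compound 3 in more than one place, so steps to it cannot be read, and whether this step would hold on a different linker remains open.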